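Benzyl to Tert-Butyl: Expected Effect on Cell Toxicity

The compounds below may be only part of what the source reports. "The series", "measured", "known", "first", "only" and "open" are said of these compounds alone.

Of the compounds shown here, three sharing one core have been tested in an ADME assay on RAW264.7 cells (Mus musculus) for cytotoxicity, read by MTT assay, with a stated time of 24 h; on this read-out lower numbers stand for higher toxicity in this test and higher numbers for lower toxicity in this test. Compound 1 `CC/C=C\CC1C(=O)C=CC1CC(=O)OC` gives 140 uM, and compound 3 `CC/C=C\C[C@H]1C(=O)C=C[C@H]1CC(=O)Oc1ccccc1OC` gives 161 uM. Compound 2 `CC/C=C\C[C@H]1C(=O)C=C[C@H]1CC(=O)OCc1ccccc1` gives 31 uM, the lowest of the three numbers and thus the most toxic in this test; the gap to each of the other two lies beyond the usual scatter. Compound 4 `CC/C=C\C[C@H]1C(=O)C=C[C@H]1CC(=O)OC(C)(C)C` has not yet been measured in this assay. Its change from compound 2 is tert-butyl in place of benzyl on an oxygen next to a carbonyl group. Among the compounds with values here, no measured pair shows this exact change, so the outlook rests on the fact that the two compounds without a benzyl group both sit well above compound 2. The expected step is a 2.9-fold higher number from compound 2 to compound 4 (0.46 log units; beyond the scatter), an increase. Compound 4 is therefore estimated at 90 uM, within a range from 35 uM to 200 uM.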

Compound 4, half-maximal toxic concentration: 33 uM
The estimate for compound 4 lay 2.7-fold (0.44 log units) above the measured number; the measured number lies below the stated range.
By their numbers in this assay, from the lowest: compounds 2 and 4 (each within the scatter of the next); then compounds 1 and 3 (each within the scatter of the next).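

Replacing benzyl with tert-butyl on an oxygen next to a carbonyl group in this assay gives a 1.1-fold higher number from compound 2 to compound 4 (0.03 log units; within the scatter). At this position, then, the toxicity reading does not depend on the six-membered aromatic ring: a smaller group with no ring serves equally well. No measurement shown here explains why these two different groups give matching numbers.

As far as these compounds go, it remains open whether any group at this position can shift the number. A longer carbon chain, or a chain ending in an amine or a carboxylic acid, would test this.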